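This account rests on a few compounds, and the source may have more. Where it says the series, first, only, none or still open, it means among the compounds named here.

The measured compounds and their values in a functional assay on OVCAR-4 cells (Homo sapiens) for inhibition, read by sulforhodamine B assay, with a stated time of 48 h; on this read-out lower numbers stand for higher toxicity in this test and higher numbers for lower toxicity in this test:

- compound 1, `COc1cc(-c2nn(-c3cccc(NC(=O)c4ccc(Cl)c(C(F)(F)F)c4)c3)cc2-c2ccncc2)ccc1Cl`, gives > 32500 nM, a limit of the assay rather than a number.
- compound 2, `COc1cc(-c2nn(-c3cccc(NC(=O)Nc4ccc(Cl)c(C(F)(F)F)c4)c3)cc2-c2ccncc2)ccc1Cl`, gives > 32500 nM, also a limit.
- compound 3, `COc1cc(-c2nn(-c3cccc(NC(=O)c4ccccc4)c3)cc2-c2ccncc2)ccc1Cl`, gives > 100000 nM, again a limit.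

Compound 2 thus stands at a limit in this assay, with no exact number known for it. Within the data shown here, the three values sit at the limit of > 32500 nM in this assay, at which 2 of the 3 values shown sit, and at the limit of > 100000 nM in this assay, at which 1 of the 3 values shown sits, so none of the measured steps can be read: a step that the two limits leave unreadable from compound 1 to compound 2, a step that the two limits leave unreadable from compound 1 to compound 3 and a step that the two limits leave unreadable from compound 2 to compound 3 all concern the group on the carbonyl carbon and all are unreadable in size.

Compound 4, `O=C(Nc1cccc(-n2cc(-c3ccncc3)c(-c3ccc(Cl)c(O)c3)n2)c1)Nc1ccc(Cl)c(C(F)(F)F)c1`, differs from compound 2 by hydrogen in place of methyl on an oxygen on an aromatic ring, turning 4-chloro-3-methoxyphenyl into 4-chloro-3-hydroxyphenyl. Among the measured compounds shown here, no measured step touches this oxygen, so nothing measured bears directly on it. For the measured compounds named here, the only anchor is compound 2, which gives > 32500 nM in this assay. Compound 4 is therefore expected to land near 50000 nM, between 15000 nM and 150000 nM, most likely reported once more as a limit. The expected step that the limit leaves unreadable from compound 2 to compound 4 is accordingly none beyond the scatter.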

Compound 4, concentration lethal to 50% of the cells: > 32500 nM
Compound 4: a limit, no number; the forecaster's own chance of this, stated with the estimate: 75%; the middle value does not contradict the limit.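

Compound 2 and compound 4 both stand at a limit of the assay rather than at a number, so the size of the change from methoxy to hydroxy cannot be read. The compounds shown leave open at what concentration, if any, they would reach the lethal end point in these cells.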